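Hydroxymethyl in Place of Carboxy on the Amide Substituent

This account rests on a few compounds, and the source may have more. Where it says the series, first, only, none or still open, it means among the compounds named here.

Three measured compounds share one core and differ only in the group on the amide-type nitrogen. In an assay on cells for agonist activity at vitamin D3 receptor (Homo sapiens), with a stated time of 96 h (a higher number here means that more compound is needed for the effect, a lower number that less compound is needed), compound 1 `CCN(CC)CCNC(=O)c1ccc(C(CC)(CC)c2ccc(OCCC(O)(CC)CC)c(C)c2)n1CC` gives 2.3 nM. Compound 2 `CCn1c(C(=O)Nc2ccc(OC(F)(F)F)cc2)ccc1C(CC)(CC)c1ccc(OCCC(O)(CC)CC)c(C)c1` reaches only > 10000 nM in this assay, which is a limit of the assay and not a number (the limit of > 10000 nM in this assay, at which 1 of the 3 values shown sits). Compound 3 `CCC(C)C(NC(=O)c1ccc(C(CC)(CC)c2ccc(OCCC(O)(CC)CC)c(C)c2)n1CC)C(=O)O` gives 860 nM in this assay, the highest of the two numbers shown, with compound 1 as its nearest neighbour. The measured steps are a 370-fold higher number from compound 1 to compound 3 (2.57 log units; beyond the scatter), an at least 4300-fold higher number from compound 1 to compound 2 (3.63 log units; beyond the scatter) and an at least 11-fold lower number from compound 2 to compound 3 (1.06 log units; beyond the scatter), all of them large, all of them at the same amide-type nitrogen.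

Compound 4 `CCC(C)C(CO)NC(=O)c1ccc(C(CC)(CC)c2ccc(OCCC(O)(CC)CC)c(C)c2)n1CC` has not been measured in this assay. It differs from compound 3 by hydroxymethyl in place of carboxy on a saturated chain carbon bound to an amide-type nitrogen and a saturated chain carbon. Among the compounds with values here, no measured step exchanges carboxy for hydroxymethyl; the three steps show only that the substituent on the amide-type nitrogen can move the number strongly in either direction, so a change beyond the scatter is possible but its direction is not fixed by the data. Compound 4 is therefore expected at 350 nM, with a range from 40 nM to 4000 nM. The expected step is a 2.5-fold lower number from compound 3 to compound 4 (0.39 log units; beyond the scatter), estimated as a modest move toward a lower number.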

Compound 4, half-maximal effective concentration: 450 nM
Beside the measured number, compound 4's estimate is 1.3-fold (0.11 log units) below it; the measured number falls inside the stated range.
By their numbers in this assay, from the lowest: compound 1; then compounds 4 and 3 (each within the scatter of the next). At a limit, above all of these: compound 2.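

Replacing carboxy with hydroxymethyl changes only the end of the substituent on the amide-type nitrogen, and in this assay it gives a 1.9-fold lower number from compound 3 to compound 4 (0.28 log units; within the scatter), so this exchange at the saturated chain carbon does not separate compound 3 from compound 4. The 1-(hydroxymethyl)-2-methylbutyl group still gives a 200-fold higher number from compound 1 to compound 4 (2.29 log units; beyond the scatter), and set against the 4-(trifluoromethoxy)phenyl group it gives an at least 22-fold lower number from compound 2 to compound 4 (1.34 log units; beyond the scatter), so with either carboxy or hydroxymethyl on this chain, the substituent remains far from the 2-(diethylamino)ethyl group of compound 1. The value of compound 2 is a limit of the assay and not a number: the limit of > 10000 nM in this assay, at which 1 of the 4 values shown sits.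

On these data alone, whether an amine or a methyl ester in place of hydroxymethyl at this carbon would stay level with compounds 3 and 4, or whether a diethylamino group on the 1-(hydroxymethyl)-2-methylbutyl chain would close the gap, remains open. The compounds shown also do not tell which part of the 2-(diethylamino)ethyl group goes with the value of compound 1, 2.3 nM.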